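Chloro for Methoxy: An Expected Growth Inhibition Value

The source may report more compounds than this note shows. Statements on the series, on what has been measured and on what is new or still open speak of the compounds shown alone.

Measured so far:
compound 1, `COc1ccc(-c2cs/c(=N\NC(=O)c3ccc(O)cc3)n2-c2ccc(OC)cc2OC)cc1`: 5370 nM
compound 2, `Cc1ccc(-c2cs/c(=N\NC(=O)c3ccc(O)cc3)n2-c2c(C)cccc2C)cc1`: 22400 nM

In a functional assay on Malme-3M cells (Homo sapiens) for cytotoxicity, read by sulforhodamine B assay, with a stated time of 48 h (on this read-out lower numbers stand for stronger inhibition of growth and higher numbers for weaker inhibition of growth), compound 1 gives 5370 nM, the lowest of the two numbers. Compound 2 gives 22400 nM, a higher number that lies beyond the usual scatter.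

Compound 3, `COc1ccc(-n2c(-c3ccc(Cl)cc3)cs/c2=N\NC(=O)c2ccc(O)cc2)c(OC)c1`, is not yet measured. It differs from compound 1 in one place: chloro in place of methoxy on an aromatic carbon. Within the data shown here, no measured pair shows this exchange, so its direction is unknown, and a step no larger than the scatter is expected: a 1.1-fold lower number from compound 1 to compound 3 (0.03 log units; within the scatter). Compound 3 is therefore estimated at 5000 nM, with a range from 1500 nM to 16000 nM.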

Compound 3, concentration for 50% growth inhibition: 25100 nM
The estimate for compound 3 lay 5.0-fold (0.70 log units) below the measured number; the whole stated range lies below it.
By their numbers in this assay, from the lowest: compound 1; then compounds 2 and 3 (each within the scatter of the next).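

In this assay, the exchange of 4-methoxyphenyl for 4-chlorophenyl gives a 4.7-fold higher number from compound 1 to compound 3 (0.67 log units; beyond the scatter) and so means weaker growth inhibition. This single-place comparison, the only one shown, gives the change a direction and shows that this position is sensitive to it. Nothing available explains the rise in the number. From the compounds shown here alone, whether an amine or a carboxylic acid at this position would restore or further weaken growth inhibition remains open. So does whether the same exchange would act alike on a different version of the shared core.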